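The compounds below may be only part of what the source reports. "The series", "measured", "known", "first", "only" and "open" are said of these compounds alone.

Compound 3, `O=C1c2c[n+]([O-])c3ccccc3c2C(=O)c2c1c1ccccc1n2CCCN1CCC(O)CC1`, gives 280 nM in a functional assay on MDA-MB-231 cells (Homo sapiens) for cytotoxicity, read by MTT assay, with a stated time of 72 h (a lower number here means a stronger inhibitor, a higher number a weaker inhibitor), the second highest of the three numbers measured. Compound 2, `CN(C)CCCCCn1c2c(c3ccccc31)C(=O)c1c[n+]([O-])c3ccccc3c1C2=O`, gives 240 nM, and the step of a 1.2-fold higher number from compound 2 to compound 3 (0.07 log units; within the scatter) lies within the scatter. Compound 1, `O=C1c2c[n+]([O-])c3ccccc3c2C(=O)c2c1c1ccccc1n2Cc1cn(C[C@@H](O)CO)nn1`, gives 670 nM, and the step of a 2.4-fold lower number from compound 1 to compound 3 (0.38 log units; beyond the scatter) is a modest one beyond the scatter. Compound 4, `O=C1c2c[n+]([O-])c3ccccc3c2C(=O)c2c1c1ccccc1n2CCN1CCCCC1`, differs from compound 3 in this way: piperidin-1-yl in place of (4-hydroxypiperidin-1-yl)methyl on a saturated chain carbon, two bonds along the chain from an aromatic nitrogen. Going by the values given here, the only step that bears on it, swapping one amine end for another at the end of the chain, is a 1.2-fold higher number from compound 2 to compound 3 (0.07 log units; within the scatter), which was within the scatter; no measured step removes a hydroxyl from such a ring or shortens the chain. Compound 4 is therefore expected to show no step beyond the scatter, a 1.1-fold higher number from compound 3 to compound 4 (0.03 log units; within the scatter), with an estimate of 300 nM in this assay, between 140 nM and 650 nM.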

Compound 4, half-maximal inhibitory concentration: 1050 nM
Compound 4: middle estimate off by 3.5-fold (0.54 log units), on the low side; the whole stated range lies below it.
By their numbers in this assay, from the lowest: compounds 2 and 3 (each within the scatter of the next); then compounds 1 and 4 (each within the scatter of the next).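

The 3-(4-hydroxypiperidin-1-yl)propyl to 2-(piperidin-1-yl)ethyl change shows that this chain is not indifferent to what it carries in this assay: the earlier amine swap stayed within the scatter, whereas here the step is a 3.8-fold higher number from compound 3 to compound 4 (0.57 log units; beyond the scatter). Against the dimethylamino chain of compound 2, the step is a 4.4-fold higher number from compound 2 to compound 4 (0.64 log units; beyond the scatter). The step to the triazole side chain, a 1.6-fold higher number from compound 1 to compound 4 (0.20 log units; within the scatter), stays within the scatter.

A 3-(piperidin-1-yl)propyl group would help separate the lost hydroxyl from the shorter chain, as both change together here. No supporting evidence explains the step.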